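Swapping a Hydroxyl for Fluorine on the Benzyl Arm

The source may report more compounds than this note shows. Statements on the series, on what has been measured and on what is new or still open speak of the compounds shown alone.

Measured so far in a functional assay on PC-3 cells (Homo sapiens) for antiproliferative activity, read by MTT assay, with a stated time of 48 h; a lower number here means a stronger inhibitor, a higher number a weaker inhibitor:
- compound 1 `COc1cc(N(Cc2ccc(C)cc2)C(=O)CSc2nc3ccccc3s2)cc(OC)c1OC`: > 80000 nM, a limit of the assay
- compound 2 `COc1ccc(CN(C(=O)CSc2nc3ccccc3s2)c2cc(OC)c(OC)c(OC)c2)cc1O`: 2110 nM
- compound 3 `COc1cc(N(Cc2ccc(Cl)cc2)C(=O)CSc2nc3ccccc3s2)cc(OC)c1OC`: > 80000 nM, also a limit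

Compound 1 stands only at a limit, and the limit of > 80000 nM in this assay, at which 2 of the 3 values shown sit, shows it shares that limit with one other compound. The change to compound 4 `COc1ccc(CN(C(=O)CSc2nc3ccccc3s2)c2cc(OC)c(OC)c(OC)c2)cc1F` is 3-fluoro-4-methoxyphenyl in place of 4-methylphenyl on a saturated chain carbon bound to an amide-type nitrogen. The nearest measured step is an at least 37-fold lower number from compound 1 to compound 2 (1.57 log units; beyond the scatter), where a hydroxyl and methoxy pair on the benzyl ring brought the number down sharply; the reverse, an at least 37-fold higher number from compound 2 to compound 3 (1.57 log units; beyond the scatter), is equally large, while a step that the two limits leave unreadable from compound 1 to compound 3 cannot be read. Compound 4 keeps the methoxy but carries fluorine where compound 2 has the hydroxyl, so a gain smaller than compound 2 achieved is expected: an at least 6.6-fold lower number from compound 1 to compound 4 (0.82 log units; beyond the scatter). Compound 4 is therefore estimated at 12000 nM, within 2500 nM to 80000 nM.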

Compound 4, half-maximal inhibitory concentration: 20100 nM
For compound 4 the middle estimate is 1.7-fold (0.22 log units) below the measured one; the measured number falls inside the stated range.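

In this assay, 3-fluoro-4-methoxyphenyl on this benzyl arm still gives a measurable number without the hydroxyl, with an at least 3.9-fold lower number from compound 1 to compound 4 (0.59 log units; beyond the scatter) and an at least 3.9-fold lower number from compound 3 to compound 4 (0.59 log units; beyond the scatter). The hydroxyl still counts, however, since fluoro in place of hydroxy gives a 9.5-fold higher number from compound 2 to compound 4 (0.98 log units; beyond the scatter). Compound 1 and compound 3 each stand at a limit, so the step between them cannot be read: the limit of > 80000 nM in this assay, at which 2 of the 4 values shown sit.

The compounds shown leave open how an amine or a carboxylic acid in place of the fluoro would compare. They also leave open how much of the gain 4-methoxyphenyl alone would keep.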